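The source may report more compounds than this note shows. Statements on the series, on what has been measured and on what is new or still open speak of the compounds shown alone.

Measured compounds in a functional assay on MGC-803 cells (Homo sapiens) for inhibition, read by MTT assay, with a stated time of 48 h; on this read-out higher numbers stand for weaker inhibition and lower numbers for stronger inhibition:
Compound 1 `CCCCC(=O)N(Cc1ccc(OC)c(O)c1)c1cc(OC)c(OC)c(OC)c1` gives 66 nM.
Compound 2 `C/C=C/C(=O)N(Cc1ccc(OC)c(OC)c1)c1cc(OC)c(OC)c(OC)c1` gives 20100 nM.
Compound 3 `COc1cc(NCc2cccc(O)c2)cc(OC)c1OC` gives 57600 nM.

Compound 1 holds the lowest number of the three, and it stands alone there: the number for compound 2 lies far above it, well beyond the scatter, and the number for compound 3 lies further still. Neither compound 2 nor compound 3 differs from compound 1 in a single place, so their values only mark how far the shared core can fall once the amide substituent and the ring substitution are altered together.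

The step of interest leads from compound 1 to compound 4 `COc1ccc(CN(C(=O)CO)c2cc(OC)c(OC)c(OC)c2)cc1O`, a change summed up as hydroxy in place of propyl on a saturated chain carbon bound to a carbonyl carbon. Among the measured compounds shown here, no measured pair shows this change on its own, so the expectation rests on compound 1 as the sole anchor, with the much weaker compounds 2 and 3 as a reminder of how wide the range can be. The acyl chain of compound 1 is cut back to a single hydroxymethyl carbonyl, and the expected step of an 18-fold higher number from compound 1 to compound 4 (1.26 log units; beyond the scatter) is a rise in the number that goes beyond the scatter, though not to the level of compound 3. Compound 4 is therefore estimated at 1200 nM, with a range from 150 nM to 9000 nM.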

Compound 4, half-maximal inhibitory concentration: 160 nM
Beside the measured number, compound 4's estimate is 7.5-fold (0.88 log units) above it; measured number inside the range.
By their numbers in this assay, from the lowest: compound 1; then compound 4; then compound 2; then compound 3.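

In this assay, the step from the butylcarbonyl chain to the (hydroxymethyl)carbonyl chain gives a 2.4-fold higher number from compound 1 to compound 4 (0.38 log units; beyond the scatter), which lies beyond the scatter but remains modest. Among the compounds shown here, this is the first change that can be read at one place alone, as the earlier compounds differed from compound 1 at the amide substituent and on the ring together and could not show what the acyl chain contributes by itself. The step shows that, with the rest of compound 1 held fixed, this position accepts hydroxy in place of propyl on a saturated chain carbon bound to a carbonyl carbon at only a modest rise in the number, although nothing measured here accounts for the size of that rise.

This single step leaves open whether the rise follows from the loss of the propyl carbons or from the entry of the hydroxy, a question that a plain acetyl chain or a longer hydroxyalkyl chain at this position would help to separate. It also leaves open how this position would respond to an amine, a methoxy group or a carboxylic acid in place of the hydroxy.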